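Replacing Hydroxy with Phenyl on the Pendant Ring of Compound 3

The source may hold more compounds than are shown below. What is called first, only, known or untested is meant among the compounds shown, and "the series" means these compounds.

Compound 1, `O=C(O)c1cc(-n2c(-c3ccccc3)cc3c2CCCC3)ccc1O`: in a functional assay on the whole organism (strain Wistar) for inhibition, with Rattus norvegicus as the target, read by paw edema, with stated times of 30 min and 3 h, at a dose of 200 mg/kg by the oral route (on this read-out lower numbers stand for less inhibition and higher numbers for more inhibition at the one dose given (going by the name of the read-out)), compound 1 gives a value that is a limit of the assay, >= 60%.
Compound 2, `O=C(O)c1cc(-n2c(-c3ccc(Cl)cc3)cc3c2CCCC3)ccc1O`: in this assay compound 2 gives 40%.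
Compound 3, `O=C(O)c1cc(-n2c(-c3ccc(O)cc3)cc3c2CCCC3)ccc1O`: in this assay compound 3 gives 20%.

Compound 3 stands lowest of the two numbers given. Its nearest neighbour is compound 2, and the step of a number 20 percentage points lower from compound 2 to compound 3 (beyond the scatter) lies beyond the scatter. The step from the parent is larger still, a number at least 40 percentage points lower from compound 1 to compound 3 (beyond the scatter), though the value of compound 1 is a limit, (the limit of >= 60% in this assay, at which 1 of the 3 values shown sits). Compound 4, `O=C(O)c1cc(-n2c(-c3ccc(-c4ccccc4)cc3)cc3c2CCCC3)ccc1O`, differs from compound 3 by phenyl in place of hydroxy on an aromatic carbon. Both measured steps that end at compound 3 bring in the hydroxy group and lower the number; neither involves phenyl, so none bears directly on its entry. Removing the hydroxy has in each case gone with a higher number, and compound 4 is therefore expected to rise, a number 25 percentage points higher from compound 3 to compound 4 (beyond the scatter), with wide uncertainty. The estimate for compound 4 in this assay is 45%, between 20% and 70%.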

Compound 4, a percentage reported as inhibition, in the whole organism at one dose (the size of the read-out at that dose, not a potency): 50%
Compound 4: the middle estimate sits 5 percentage points below what was measured; the measured number falls inside the stated range.
By their numbers in this assay, from the lowest: compound 3; then compounds 2 and 4 (each within the scatter of the next). At a limit, above all of these: compound 1.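

In this assay, the low number of compound 3 proves not to hold for every group at this position, since phenyl in place of hydroxy brings a clear recovery: a number 30 percentage points higher from compound 3 to compound 4 (beyond the scatter). Phenyl and chloro cannot be ordered here, given a number 10 percentage points higher from compound 2 to compound 4 (within the scatter), so the large phenyl group fits at this place at least as well as far as the read-out can tell. Nor does the comparison with hydrogen show any cost of phenyl, with a number at least 10 percentage points lower from compound 1 to compound 4 (that floor lies within the scatter), and the value of compound 1 is a limit: the limit of >= 60% in this assay, at which 1 of the 4 values shown sits.

As far as these compounds go, it remains open whether a methoxy group, an amine or a carboxylic acid at this position would give a number as low as that of compound 3. The compounds shown also leave open why hydroxy goes with the lowest number.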